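A Smaller Amine End and an Expected Flat Step

The source may hold more compounds than are shown below. What is called first, only, known or untested is meant among the compounds shown, and "the series" means these compounds.

Of the compounds shown here, three sharing one core have been measured in an assay on cells for inhibition of Voltage-dependent T-type calcium channel subunit alpha-1H (Homo sapiens), read by FLIPR and calcium flux, with stated times of 600 s and 300 s; a lower number here means a stronger inhibitor, a higher number a weaker inhibitor. Compound 1 `CN(Cc1ccc(OCCCN)cc1)c1nc2ccc(Oc3ccc(C#N)cc3)cc2s1` gives 328000 nM in this assay. Compound 2 `CN(Cc1ccc(OCCCNC(=N)N)cc1)c1nc2ccc(Oc3ccc(C(F)(F)F)cc3)cc2s1` gives 212000 nM, and compound 3 `NCCCOc1ccc(CNc2nc3ccc(Oc4ccc(O)cc4)cc3s2)cc1` gives 300000 nM. Compound 2 holds the lowest of the three numbers, yet its distance to compound 3 and to compound 1 lies within the scatter of repeated measurements, so no order among the three can be read from these values; all three are weak inhibitors in this assay.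

Compound 4 `CN(Cc1ccc(OCCCN)cc1)c1nc2ccc(Oc3ccc(C(F)(F)F)cc3)cc2s1` has not yet been measured. It differs from compound 2 in one place: a hydrogen atom in place of a group of 3 heavy atoms (1 carbon, 2 nitrogen; no ring), on an amine nitrogen. Among the compounds with values here, no pair of measured compounds differs only at this place, so the size of this step cannot be taken from earlier data. Compound 1 and compound 3 both carry hydrogen on the corresponding amine nitrogen, differing from compound 4 elsewhere, and in this assay compound 1 gives 328000 nM while compound 3 gives 300000 nM, both close to compound 2. The step is expected to be small and not beyond the scatter, a 1.4-fold higher number from compound 2 to compound 4 (0.15 log units; within the scatter). Compound 4 is expected to give about 300000 nM in this assay, within a range from 150000 nM to 600000 nM.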

Compound 4, half-maximal inhibitory concentration: 248000 nM
Beside the measured number, compound 4's estimate is 1.2-fold (0.08 log units) above it; low and high end bracket the measured number.
By their numbers in this assay, from the lowest: compounds 2, 4, 3 and 1 (each within the scatter of the next).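

In this assay, within the data shown here, the first single-place pair at this amine nitrogen, whose other neighbour is a saturated chain carbon, gives a 1.2-fold higher number from compound 2 to compound 4 (0.07 log units; within the scatter) when a hydrogen atom takes the place of the group of 3 heavy atoms (1 carbon, 2 nitrogen; no ring). Among these compounds, the same new compound also provides the first single-place pair on the aromatic carbon, where trifluoromethyl in place of cyano gives a 1.3-fold lower number from compound 1 to compound 4 (0.12 log units; within the scatter), so neither change separates its two compounds beyond the scatter, and all the numbers remain high. Nothing available explains the size of either step.

The compounds shown leave open whether any other group at these places would give a number beyond the scatter, such as a carboxylic acid or a longer chain in place of the amine end, or chlorine or a methoxy group in place of trifluoromethyl. Among the compounds shown here, the effect of the methyl group on the nitrogen attached to the shared core, and of the hydroxyl group in compound 3, cannot be read, as no single-place pair isolates either one.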